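The compounds below may be only part of what the source reports. "The series", "measured", "known", "first", "only" and "open" are said of these compounds alone.

Compound 1 `COc1cc(-c2cc(/C=C/C(=O)c3ccc(N)cc3)[nH]n2)cc(OC)c1OC` gives 1570 nM in a functional assay on OVCAR-3 cells (Homo sapiens) for inhibition, read by sulforhodamine B assay, with a stated time of 48 h (on this read-out lower numbers stand for stronger inhibition of growth and higher numbers for weaker inhibition of growth), the lowest of the two numbers seen, though compound 2 `COc1ccc(-c2cc(/C=C/C(=O)c3ccc(N)cc3)[nH]n2)cc1OC`, which gives 1920 nM in this assay, sits within the scatter of it, the step of a 1.2-fold higher number from compound 1 to compound 2 (0.09 log units; within the scatter). Compound 3 `COc1cc(-c2cc(/C=C/C(=O)c3ccc(F)c(F)c3)[nH]n2)cc(OC)c1OC` differs from compound 1 by 3,4-difluorophenyl in place of 4-aminophenyl on a carbonyl carbon. Going by the values given here, no measured step touches the carbonyl carbon, and the one step known lies elsewhere and within the scatter, so the data give little guidance here. Compound 3 is therefore expected to show a 1.6-fold higher number from compound 1 to compound 3 (0.20 log units; within the scatter), with wide uncertainty, an estimated 2500 nM between 900 nM and 7000 nM.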

Compound 3, concentration for 50% growth inhibition: 2390 nM
Compound 3: middle estimate off by 1.0-fold (0.02 log units), on the high side; measured number inside the range.
By their numbers in this assay, from the lowest: compounds 1, 2 and 3 (each within the scatter of the next).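

Placing 3,4-difluorophenyl in place of 4-aminophenyl on a carbonyl carbon gives a 1.5-fold higher number from compound 1 to compound 3 (0.18 log units; within the scatter) in this assay and is the first step read at this position. So the exchange, which takes away the hydrogen-bond donor and acceptor counted for 4-aminophenyl, moves the number by no more than the scatter. Nothing measured here bears on this result.

As far as these compounds go, whether a nitrile or a carboxylic acid on this aromatic ring would also stay within the scatter remains open. So does whether the same exchange would behave alike on the core of compound 2.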